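Adding a Nitro Group to the Core of Compound 2

The compounds below may be only part of what the source reports. "The series", "measured", "known", "first", "only" and "open" are said of these compounds alone.

Three amides built on one shared core have been measured. Compound 1 `Cc1ccccc1NC(=O)c1cc2ccccc2oc1=O` gives 2960 nM in an assay for inhibition of Amine oxidase [flavin-containing] B (Homo sapiens), read by fluorescence, using microsomes, with a stated time of 15 min; a higher number here means a weaker inhibitor, a lower number a stronger inhibitor. Compound 2 `Cc1cccc(NC(=O)c2cc3ccccc3oc2=O)c1` gives 930 nM, and compound 3 `O=C(Nc1cccc(C(F)(F)F)c1)c1cc2ccccc2oc1=O` gives 3300 nM. Compound 2 stands lowest of the three: the step of a 3.2-fold lower number from compound 1 to compound 2 (0.50 log units; beyond the scatter) and the step of a 3.5-fold higher number from compound 2 to compound 3 (0.55 log units; beyond the scatter) both lie beyond the scatter, so compound 2 is the strongest inhibitor shown. Compound 4 `Cc1cccc(NC(=O)c2cc3cc([N+](=O)[O-])ccc3oc2=O)c1` differs from compound 2 by nitro in place of hydrogen on an aromatic carbon. Both measured steps change the ring on the amide nitrogen, not the core, so neither bears directly on this change. With no guide from the data, the step of a 1.0-fold lower number from compound 2 to compound 4 (0.01 log units; within the scatter) is expected to lie within the scatter. Compound 4 is therefore estimated at 900 nM, with a range from 300 nM to 3000 nM.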

Compound 4, half-maximal inhibitory concentration: 39100 nM
Compound 4: middle estimate off by 43-fold (1.64 log units), on the low side, outside the stated range (above it).
By their numbers in this assay, from the lowest: compound 2; then compounds 1 and 3 (each within the scatter of the next); then compound 4.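

The earlier steps shown here changed only the ring on the amide nitrogen, whereas this one shows that the core itself can matter. In this assay nitro in place of hydrogen on this aromatic carbon gives a 42-fold higher number from compound 2 to compound 4 (1.62 log units; beyond the scatter) and so weakens inhibition far more than either change to the amide ring did. No available measurement explains this drop. The compounds shown leave open whether an amine, a methoxy group or a fluorine atom at this carbon would weaken inhibition as well. They also leave open whether nitro elsewhere on the core would do the same.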